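Fluoro to ethoxycarbonyl at the assay limit

This account rests on a few compounds, and the source may have more. Where it says the series, first, only, none or still open, it means among the compounds named here.

Measured in a functional assay on Hep 3B2 cells (Homo sapiens) for cytotoxicity, read by MTT assay, with a stated time of 6 days; on this read-out higher numbers stand for weaker inhibition and lower numbers for stronger inhibition:
compound 1 `Cc1ccc2c(c1)OCC(=O)N2Cc1cn(Cc2ccccc2)nn1`: > 100000 nM
compound 2 `O=C1COc2ccc(F)cc2N1Cc1cn(Cc2ccccc2)nn1`: > 100000 nM

Compound 1 stands at > 100000 nM as a limit and not a number. Compound 2 stands at > 100000 nM as a limit and not a number. The whole record so far is the limit of > 100000 nM in this assay, at which 2 of the 2 values shown sit, and no step can be read from it. Compound 3 `CCOC(=O)c1ccc2c(c1)N(Cc1cn(Cc3ccccc3)nn1)C(=O)CO2` carries the change ethoxycarbonyl in place of fluoro on an aromatic carbon on the shared core. The estimated a number no higher from compound 2 to compound 3 (the limit leaves the size open) in this assay is expected to stay within the scatter, in neither direction. For compound 3 the estimate is 100000 nM with an expected range of 30000 nM to 200000 nM and a limit rather than a number is likely.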

Compound 3, half-maximal inhibitory concentration: 17100 nM
Estimate against measurement, compound 3: 5.8-fold (0.77 log units) above; the measured number lies below the stated range.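

In this assay, ethoxycarbonyl in place of fluoro on this aromatic carbon of the shared core gives an at least 5.8-fold lower number from compound 2 to compound 3 (0.76 log units; beyond the scatter). Within the data shown here, compound 3 is the first compound here with a number rather than a limit, so this position can move the read-out, which compound 1 and compound 2 could not show. The size of the step stays open because compound 2 stands at a limit: the limit of > 100000 nM in this assay, at which 2 of the 3 values shown sit.

The compounds shown leave open whether the whole ethoxycarbonyl or only its carbonyl carries the change. A carboxylic acid or a longer ester chain on the same carbon would separate the two.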